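Swapping the Amide Cap on a Sigma-1 Binder

The source may hold more compounds than are shown below. What is called first, only, known or untested is meant among the compounds shown, and "the series" means these compounds.

Compound 2 `CC(C)(C)C(=O)N1CCC(NCCSC(c2ccc(F)cc2)c2ccc(F)cc2)CC1` gives 163 nM in an assay on membranes from Cortex for displacement of a labelled ligand from Sigma non-opioid intracellular receptor 1 (Cavia porcellus), read by scintillation counting, with a stated time of 120 min; on this read-out lower numbers stand for stronger inhibition and higher numbers for weaker inhibition. Within the data shown here, its only measured neighbour, compound 1 `Fc1ccc(C(SCCNC2CCN(Cc3ccc(C(F)(F)F)cc3)CC2)c2ccc(F)cc2)cc1`, gives 186 nM, and the two numbers lie within the scatter of each other, so neither stands apart. Among the measured compounds shown here, the step of a 1.1-fold lower number from compound 1 to compound 2 (0.06 log units; within the scatter) is the single measured change available, and it exchanged the whole group on the amine nitrogen in the ring without moving the read-out. Compound 3 `O=C(c1ccccc1F)N1CCC(NCCSC(c2ccc(F)cc2)c2ccc(F)cc2)CC1` differs from compound 2 by 2-fluorophenyl in place of tert-butyl on a carbonyl carbon. One unmoved step at a nearby position is slender ground, yet it is all that exists here, so the step from compound 2 to compound 3 is expected to be a 1.0-fold higher number from compound 2 to compound 3 (0.02 log units; within the scatter), with no shift beyond the scatter in either direction. Compound 3 is therefore estimated at 170 nM in this assay, with a range from 55 nM to 520 nM.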

Compound 3, inhibition constant: 3.57 nM
Compound 3: middle estimate off by 48-fold (1.68 log units), on the high side; the measured number lies below the stated range.
By their numbers in this assay, from the lowest: compound 3; then compounds 2 and 1 (each within the scatter of the next).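

Replacing the tert-butyl group on the carbonyl with 2-fluorophenyl gives a 46-fold lower number from compound 2 to compound 3 (1.66 log units; beyond the scatter) in this assay and shows that this position can strongly affect the read-out. The values of compound 1 and compound 2 lie within the scatter of each other, so that earlier pair gave no sign of a change this large. The comparison with the 4-(trifluoromethyl)benzyl group on the amine nitrogen in the ring points the same way, with a 52-fold lower number from compound 1 to compound 3 (1.72 log units; beyond the scatter) and no information in the data on what lies behind either gain.

As far as these compounds go, it remains open whether the gain needs the aromatic ring alone or also its fluorine, a question that an unsubstituted phenyl group on the same carbonyl could address. A cyclohexyl group there could likewise test whether an aromatic ring is needed at all.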